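Bromine position on the aryl ring and Caco-2 inhibition

The source may hold more compounds than are shown below. What is called first, only, known or untested is meant among the compounds shown, and "the series" means these compounds.

Compound 1 `Fc1ccc(/C=N/Nc2nc(-c3cccc(Br)c3)cs2)cc1F` and compound 2 `Fc1ccc(/C=N/Nc2nc(-c3ccc(Br)cc3)cs2)cc1F` share one core and differ only in the bromophenyl group. In a functional assay on Caco-2 cells (Homo sapiens) for inhibition, read by MTT assay, with a stated time of 48 h (a lower number here means a stronger inhibitor, a higher number a weaker inhibitor), compound 1 gives 17500 nM. In the same assay compound 2 gives 43900 nM. The change 4-bromophenyl in place of 3-bromophenyl on an aromatic carbon thus produced a 2.5-fold higher number from compound 1 to compound 2 (0.40 log units; beyond the scatter).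

Compound 3 `COc1cc(/C=N/Nc2nc(-c3cccc(Br)c3)cs2)c(Br)c(Br)c1OC` is built on a different core; the difference between the two cores is not broken down here. In this assay compound 3 reaches only the limit of the measurement, > 100000 nM. Of note is the limit of > 100000 nM in this assay, at which 1 of the 3 values shown sits.

Compound 4 `COc1cc(/C=N/Nc2nc(-c3ccc(Br)cc3)cs2)c(Br)c(Br)c1OC` has not been measured. It relates to compound 3 exactly as compound 2 relates to compound 1, through (4-bromophenyl in place of 3-bromophenyl on an aromatic carbon); the surroundings of the change are the same in both pairs, so this is the same change. For compound 4 a weakening of about the same size as seen earlier is expected, because compound 3 already sits at the limit and the move from compound 1 to compound 2 gave a 2.5-fold higher number from compound 1 to compound 2 (0.40 log units; beyond the scatter). Compound 4 is therefore estimated at 250000 nM. That estimate implies an expected step that the limit leaves unreadable from compound 3 to compound 4, with the assay most likely again reporting only a limit.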

Compound 4, half-maximal inhibitory concentration: > 100000 nM
Compound 4: a limit, no number; the forecaster's own chance of this, stated with the estimate: 90%; the middle value does not contradict the limit.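

In this assay compound 3 and compound 4 both stand at a limit of the assay, not at a number, so no step between them can be read: the limit of > 100000 nM in this assay, at which 2 of the 4 values shown sit.

The compounds shown leave open whether 4-bromophenyl in place of 3-bromophenyl changes inhibition on the core of compound 3 as it does on the core of compound 1.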